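The source may report more compounds than this note shows. Statements on the series, on what has been measured and on what is new or still open speak of the compounds shown alone.

Working notes on the series

The benzimidazole pair with a shared dichlorinated core is measured first. Compound 3 `O=[N+]([O-])c1ccc(-c2nc3cc(Cl)c(Cl)cc3[nH]2)cc1` gives 17000 nM in an ADME assay on MT4 cells (Homo sapiens) for cytotoxicity, read by MTT assay, with a stated time of 96 h; a lower number here means that less compound is tolerated, a higher number that more compound is tolerated. Compound 1 `Nc1ccc(-c2nc3cc(Cl)c(Cl)cc3[nH]2)cc1` gives 17000 nM in this assay, so the step of no change at the digits printed from compound 3 to compound 1 (within the scatter); the change behind it is amino in place of nitro on an aromatic carbon.

Going by the values given here, compound 2 `O=[N+]([O-])c1ccc(-c2nc3cc(C(F)(F)F)ccc3n2C2CCCCC2)cc1` gives 49000 nM in this assay, the highest of the three numbers so far; the difference between its core and the core of compound 3 is not broken down here, and what the two values show is a gap beyond the scatter.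

Compound 4 `Nc1ccc(-c2nc3cc(C(F)(F)F)ccc3n2C2CCCCC2)cc1` has not yet been measured in this assay. It stands to compound 2 as compound 1 stands to compound 3: the change is amino in place of nitro on an aromatic carbon, and the place lines of the two changes read the same word for word, so this is the same change made a second time; among the compounds shown it occurs twice in all.

Among the compounds with values here, the expectation for compound 4 rests on the one measured instance of this change, where the step of no change at the digits printed from compound 3 to compound 1 (within the scatter). On that basis the step from compound 2 to compound 4 is expected to be no change at the digits printed from compound 2 to compound 4 (within the scatter) in this assay, that is, no step beyond the scatter. Compound 4 is therefore estimated at 49000 nM in this assay, with a plausible range from 24000 nM to 100000 nM; a single precedent on a different core is a thin basis, so the range is kept wide.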

Compound 4, half-maximal cytotoxic concentration: 44000 nM
Estimate against measurement, compound 4: 1.1-fold (0.05 log units) above, within the range that was stated.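

The step from nitro to amino has now been read on a second core in this assay, and it is a 1.1-fold lower number from compound 2 to compound 4 (0.05 log units; within the scatter). Set beside the earlier step, the change carries from one core to the other without a difference that stands out of the scatter: the same change on two cores in this assay, no change at the digits printed (within the scatter) from compound 3 to compound 1 and a 1.1-fold lower number (0.05 log units; within the scatter) from compound 2 to compound 4, 1.1-fold (0.05 log units) apart, within the scatter of two such steps. This shows that, on these two cores, going from 4-nitrophenyl to 4-aminophenyl leaves the half-maximal cytotoxic concentration where it was, so the outcome on one core was a fair guide to the outcome on the other; it does not show that the same would hold on a third core, it gives no reason for the flat result, and two pairs are too few to call it a rule for the series.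

The compounds shown leave open whether other groups at the same place on the aromatic ring, such as a carboxylic acid or a nitrile, would also give numbers within the scatter of those for nitro and amino. They also leave open which of the several differences between the two cores accounts for the gap between their values, since no pair shown changes only one of them.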